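Amide chain length in a shared core: antiproliferative notes

The source may hold more compounds than are shown below. What is called first, only, known or untested is meant among the compounds shown, and "the series" means these compounds.

Of the compounds shown here, three on one core have been measured and a fourth awaits a number. Compound 1 `CCC1C(=O)N(C)c2cnc(-n3ccc4cc(C(=O)NC)ccc43)nc2N1c1ccn(C)n1`, compound 2 `CCCNC(=O)c1ccc2c(ccn2-c2ncc3c(n2)N(c2ccn(C)n2)C(CC)C(=O)N3C)c1` and compound 3 `CCCCNC(=O)c1ccc2c(ccn2-c2ncc3c(n2)N(c2ccn(C)n2)C(CC)C(=O)N3C)c1` differ only in the chain on the amide nitrogen. In a functional assay on K562 cells (Homo sapiens) for antiproliferative activity, read by CCK-8 assay, with a stated time of 72 h (on this read-out higher numbers stand for weaker inhibition of growth and lower numbers for stronger inhibition of growth), compound 1 gives 13300 nM, compound 2 gives 8270 nM and compound 3 gives 14100 nM. All three numbers sit close together: a 1.6-fold higher number from compound 2 to compound 1 (0.21 log units; within the scatter), a 1.1-fold higher number from compound 1 to compound 3 (0.03 log units; within the scatter) and a 1.7-fold higher number from compound 2 to compound 3 (0.23 log units; within the scatter). The change between compound 2 and compound 1 is hydrogen in place of ethyl on a saturated chain carbon bound to an amide-type nitrogen. The change between compound 2 and compound 3 is methyl in place of hydrogen on a saturated chain carbon, three bonds along the chain from an amide-type nitrogen.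

Compound 4 `CCNC(=O)c1ccc2c(ccn2-c2ncc3c(n2)N(c2ccn(C)n2)C(CC)C(=O)N3C)c1` is the unmeasured member. It differs from compound 3 by hydrogen in place of ethyl on a saturated chain carbon, two bonds along the chain from an amide-type nitrogen. Among the compounds with values here, this is the same kind of change as the one from compound 2 to compound 1, although the place is not the same: there the ethyl left a saturated chain carbon bound to an amide-type nitrogen, here it leaves a saturated chain carbon two bonds along the chain from an amide-type nitrogen. Since shortening the chain gave only a 1.6-fold higher number from compound 2 to compound 1 (0.21 log units; within the scatter), and every step among compound 1, compound 2 and compound 3 stays within the scatter, compound 4 is expected to land near its neighbours. The expected step is a 1.4-fold lower number from compound 3 to compound 4 (0.15 log units; within the scatter) in this assay, resting on the flat run across compound 1, compound 2 and compound 3. The estimate for compound 4 in this assay is 10000 nM, with an expected range from 5000 nM to 22000 nM.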

Compound 4, concentration for 50% growth inhibition: 12800 nM
The estimate for compound 4 lay 1.3-fold (0.11 log units) below the measured number, and the stated range covers the measured number.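

Hydrogen in place of ethyl reads alike at its two places on the amide chain in this assay: the same change on two cores in this assay, a 1.6-fold higher number (0.21 log units; within the scatter) from compound 2 to compound 1 and a 1.1-fold lower number (0.04 log units; within the scatter) from compound 3 to compound 4, 1.8-fold (0.25 log units) apart, within the scatter of two such steps. The methyl change also reads alike in its two settings: the same change on two cores in this assay, a 1.7-fold higher number (0.23 log units; within the scatter) from compound 2 to compound 3 and a 1.0-fold lower number (0.02 log units; within the scatter) from compound 1 to compound 4, 1.8-fold (0.25 log units) apart, within the scatter of two such steps. With a 1.1-fold lower number from compound 3 to compound 4 (0.04 log units; within the scatter), a 1.5-fold higher number from compound 2 to compound 4 (0.19 log units; within the scatter) and a 1.0-fold lower number from compound 1 to compound 4 (0.02 log units; within the scatter), all the new steps are too small to tell apart from repeat scatter, so the series shows that these changes carry from one core to another without a visible gap, but not that chain length moves growth inhibition at all, nor that a step of real size would carry over.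

The compounds shown span only unbranched chains on the amide nitrogen, from methyl to butyl, so it remains open whether a longer chain, a branched chain, or a chain ending in an amine or a carboxylic acid would move the number beyond the scatter. Also open, from the compounds shown here alone, is whether the flat run would hold with a second methyl in place of the amide hydrogen.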